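The compounds below may be only part of what the source reports. "The series", "measured", "known", "first", "only" and "open" are said of these compounds alone.

Series notes. Among the compounds with values here, compound 2 `CCCC[C@@H](/C=C\[C@@H]1OC(=O)C=C[C@@H]1O)OC(C)=O` sits at the low end of the numbers so far: in a functional assay on LNCaP cells (Homo sapiens) for cytotoxicity, read by sulforhodamine B assay, with a stated time of 72 h (a lower number here means that less compound is needed, a higher number that more compound is needed for the effect), compound 2 gives 0.8 ug/mL. The nearest number belongs to compound 1 `CCCC[C@H](OC(C)=O)[C@@H](O)[C@H](O)[C@@H]1OC(=O)C=C[C@@H]1OC(C)=O`, which in this assay gives 4.5 ug/mL, a gap beyond the usual scatter of the measurement. Compound 3 `CCCC[C@@H](/C=C\[C@@H]1OC(=O)C[C@@H](OC)[C@@H]1O)OC(C)=O` returns only a limit of the assay, > 20 ug/mL, and not a number; this is the limit of > 20 ug/mL in this assay, at which 1 of the 3 values shown sits. Compound 4 `CCCC[C@@H](/C=C\[C@@H]1OC(=O)C=C[C@@H]1OC(C)=O)OC(C)=O` has not yet been measured in this assay. It differs from compound 2 in one place: acetyl in place of hydrogen on an oxygen on a saturated carbon. Within the data shown here, no measured pair in the set shows this same change, so its effect cannot be read from the data and rests on expectation alone. The change is expected to cost little or nothing beyond the scatter; the step expected is a 1.5-fold higher number from compound 2 to compound 4 (0.18 log units; within the scatter), a slight move toward a higher number at most. Compound 4 is therefore expected to give 1.2 ug/mL, with a range of 0.4 ug/mL to 3.5 ug/mL in this assay.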

Compound 4, concentration for half-maximal effect: 0.7 ug/mL
For compound 4 the middle estimate is 1.7-fold (0.23 log units) above the measured one; the range from low to high includes it.
By their numbers in this assay, from the lowest: compounds 4 and 2 (each within the scatter of the next); then compound 1. At a limit, above all of these: compound 3.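

In this assay, within the data shown here, the change from hydroxy to acetoxy gives a 1.1-fold lower number from compound 2 to compound 4 (0.06 log units; within the scatter) and so the first direct reading of this position: the free hydroxy on a saturated carbon is not required for this read-out, and acetyl is accepted on that oxygen. Compound 1 and compound 3 could not show this, since each differs from compound 2 in more than one place and neither forms a step with it. No measurement shown bears on the reason for this result.

As far as these compounds go, whether the position accepts groups other than acetyl stays open: a longer acyl chain such as hexanoyl, a methyl ether or an amine in place of the oxygen would test this. Also open, from the compounds shown here alone, is whether acetyl on this oxygen reads the same on the saturated lactone core of compound 3.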